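This account rests on a few compounds, and the source may have more. Where it says the series, first, only, none or still open, it means among the compounds named here.

Of the compounds shown here, two have so far been measured in a functional assay on BGC-823 cells (Homo sapiens) for cytotoxicity, read by MTT assay, with a stated time of 48 h; on this read-out lower numbers stand for stronger inhibition and higher numbers for weaker inhibition. Compound 1 `CCCCCCCCOc1ccc2c(Cl)ccnc2c1` gives 4300 nM there, the higher of the two numbers. Compound 2 `CCOc1ccc2c(NCCN(C)C)ccnc2c1` gives 2520 nM in this assay, and the two values lie within the scatter of each other, so no order between them can be read from these numbers alone.

Compound 3 `Clc1ccnc2cc(OCCc3ccccc3)ccc12` has not yet been measured. It differs from compound 1 in one place: phenyl in place of hexyl on a saturated chain carbon, two bonds along the chain from an oxygen on an aromatic ring. Within the data shown here, no measured pair in the set carries this same change, so its effect cannot be read off anything already known, and the value of compound 1 at 4300 nM is the only anchor. In this assay the step is expected to be a 1.1-fold lower number from compound 1 to compound 3 (0.03 log units; within the scatter), a change no larger than the usual scatter. Compound 3 is accordingly expected to give about 4000 nM, with a range from 1500 nM to 11000 nM.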

Compound 3, half-maximal inhibitory concentration: 2010 nM
The estimate for compound 3 lay 2.0-fold (0.30 log units) above the measured number; low and high end bracket the measured number.
By their numbers in this assay, from the lowest: compounds 3, 2 and 1 (each within the scatter of the next, the first and the last beyond it).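

In this assay, phenyl in place of hexyl on a saturated chain carbon, two bonds along the chain from an oxygen on an aromatic ring, gives a 2.1-fold lower number from compound 1 to compound 3 (0.33 log units; beyond the scatter). Among these compounds, this is the first step that can be read, and it shows that the number at this position responds to the group placed there. Hexyl and phenyl have the same count of heavy atoms, all carbon, and neither has hydrogen-bond donors or acceptors, so the ring is what separates them in these counts, but nothing measured here explains the step.

As far as these compounds go, whether the ring's aromatic character matters remains open, as cyclohexyl at the same place would be needed to tell. The compounds shown also leave open whether a pyridine ring or a fluorine-bearing phenyl would move the number further.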